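Succinimide Piperazine Amides: Aryl Methyl for Trifluoromethyl

A few compounds are considered here, and "the series" means these few. Any claim that something is new, unique, unknown or untested is made for them only; others in the source may bear on it.

Measured so far:
compound 1, `CCC(C(=O)N1CCN(c2cccc(C(F)(F)F)c2)CC1)N1C(=O)CCC1=O` — in a functional assay on the whole organism (strain Swiss) with Mus musculus as the target, in the maximal electroshock model, with a stated time of 0.25 h, at a dose of 100 mg/kg by the intraperitoneal route (a higher number here means a stronger effect of the compound at the dose given, a lower number a weaker effect), compound 1 gives 75%
compound 2, `CCC(C(=O)N1CCN(c2cccc(C)c2)CC1)N1C(=O)CCC1=O` — in this assay compound 2 gives 50%
compound 3, `CC(C(=O)N1CCN(c2cccc(C(F)(F)F)c2)CC1)N1C(=O)CCC1=O` — in this assay compound 3 gives 50%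

Two single changes from compound 1 are known. The first, (methyl in place of trifluoromethyl on an aromatic carbon), gave a number 25 percentage points lower from compound 1 to compound 2 (beyond the scatter). The second, (hydrogen in place of methyl on a saturated chain carbon, two bonds along the chain from an amide-type nitrogen in a ring and a carbonyl carbon), gave a number 25 percentage points lower from compound 1 to compound 3 (beyond the scatter). Compound 2 and compound 3 stand level with each other within the scatter.

Compound 4, `Cc1cccc(N2CCN(C(=O)C(C)N3C(=O)CCC3=O)CC2)c1`, is not yet measured. Its core differs from that of compound 2 by hydrogen in place of methyl on a saturated chain carbon, two bonds along the chain from an amide-type nitrogen in a ring and a carbonyl carbon. The change from compound 3 to compound 4 is methyl in place of trifluoromethyl on an aromatic carbon; its place reads the same as for the change from compound 1 to compound 2, so it is the same change made on the other core. For the measured compounds named here, only this one earlier instance is available, so a repeat of that size is the natural expectation, without any check on whether the two cores respond alike.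

From compound 3 to compound 4 the expected step is a number 25 percentage points lower from compound 3 to compound 4 (beyond the scatter), resting on the earlier a number 25 percentage points lower from compound 1 to compound 2 (beyond the scatter). Compound 4 is therefore estimated at 25% in this assay, within 0% to 50%.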

Compound 4, a percentage reported as activity, at one dose (the size of the read-out at that dose, not a potency): 0%
For compound 4 the middle estimate is 25 percentage points above the measured one, within the range that was stated.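

In this assay, methyl in place of trifluoromethyl on the aromatic carbon gives a number 50 percentage points lower from compound 3 to compound 4 (beyond the scatter), so the size of this change did not carry over from the core of compound 1: the same change on two cores in this assay, a number 25 percentage points lower (beyond the scatter) from compound 1 to compound 2 and a number 50 percentage points lower (beyond the scatter) from compound 3 to compound 4, 25 percentage points apart, beyond the scatter of two such steps

Hydrogen in place of methyl on the saturated chain carbon gives a number 50 percentage points lower from compound 2 to compound 4 (beyond the scatter), and this change also differs in size between the two cores: the same change on two cores in this assay, a number 25 percentage points lower (beyond the scatter) from compound 1 to compound 3 and a number 50 percentage points lower (beyond the scatter) from compound 2 to compound 4, 25 percentage points apart, beyond the scatter of two such steps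

Across these four compounds, each change kept its direction while its size depended on the group at the other place, so the two changes do not simply add; this rests on one pair of cores per change and does not show why the sizes differ or how a further core would respond.

The compounds shown leave open whether chlorine or methoxy on the aromatic carbon, or a longer chain on the saturated chain carbon, would follow the same pattern. They also leave open whether the dependence on the core would hold at another dose or time.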